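The source may report more compounds than this note shows. Statements on the series, on what has been measured and on what is new or still open speak of the compounds shown alone.

Of the compounds shown here, three built on one shared core have been measured in an ADME assay (liver) for metabolic stability, with Liver microsome (Homo sapiens) as the target, using microsomes; a higher number here means faster removal of the compound, a lower number slower removal. Compound 1 (`Cc1cnc(NC(=O)c2cc(Oc3cnc(C(=O)N(C)C)cn3)c3cc(C)oc3c2)cn1`) gives < 8.5 mL/min/kg, which is a limit. Compound 2 (`Cc1cnc(NC(=O)c2cc(Oc3cnc(C(=O)N(C)C)nc3)c3cc(C)oc3c2)cn1`) gives < 8 mL/min/kg, which is also a limit. Within the data shown here, compound 3 (`Cc1cnc(NC(=O)c2cc(Oc3ccc(S(C)(=O)=O)cc3)c3cc(C)oc3c2)cn1`), at 13 mL/min/kg, therefore holds the only actual number among the three. Compound 4 (`Cc1cnc(NC(=O)c2cc(Oc3ccc(C(=O)N(C)C)cc3)c3cc(C)oc3c2)cn1`) differs from compound 3 by having dimethylcarbamoyl in place of methylsulfonyl on an aromatic carbon, para to a large group: dimethylcarbamoyl in place of methylsulfonyl on an aromatic carbon. Among the measured compounds shown here, no measured pair shows this exchange on its own. The expected 1.2-fold higher number from compound 3 to compound 4 (0.06 log units; within the scatter) is no larger than the usual scatter in this assay. Compound 4 is estimated at 15 mL/min/kg, with an expected range from 8 mL/min/kg to 28 mL/min/kg.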

Compound 4, clearance: 17 mL/min/kg
Compound 4: the middle estimate sits 1.1-fold (0.05 log units) below what was measured; low and high end bracket the measured number.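

In this assay, dimethylcarbamoyl in place of methylsulfonyl on an aromatic carbon, para to a large group, gives a 1.3-fold higher number from compound 3 to compound 4 (0.12 log units; within the scatter). Among these compounds, this is the first step that can be read at this position, and it shows that these two groups can be exchanged here without a change beyond the scatter. Nothing shown bears on why the step is this size.

On these data alone, whether an amine or a carboxylic acid on this same aromatic carbon would give a step beyond the scatter stays open. So does whether this exchange would read the same on another core.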